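A few compounds are considered here, and "the series" means these few. Any claim that something is new, unique, unknown or untested is made for them only; others in the source may bear on it.

In a physicochemical assay for solubility, using the shake flask method, measured as kinetic solubility, with a stated time of 20 h, at pH 2 (on this read-out higher numbers stand for higher solubility and lower numbers for lower solubility), compound 1 `COc1cccnc1Nc1cc2[nH]c(-c3cccc(C(F)(F)F)c3)nc2cn1` gives 116000 nM. Compound 2 `COc1ccc(Nc2cc3[nH]c(-c4cccc(C(F)(F)F)c4)nc3cn2)nc1` gives < 5000 nM, which is a limit of the assay and not a number. This places compound 2 at the limit of < 5000 nM in this assay, at which 1 of the 2 values shown sits. For the measured compounds named here, the one measured step is an at least 23-fold lower number from compound 1 to compound 2 (1.36 log units; beyond the scatter). It is large, but it only relocates the methoxy group, so it bears on the next change only indirectly: it shows that this read-out can respond strongly to an edit on that ring. Compound 3 `CN1CCN(c2ccc(Nc3cc4[nH]c(-c5cccc(C(F)(F)F)c5)nc4cn3)nc2)CC1` carries 4-methylpiperazin-1-yl in place of methoxy on an aromatic carbon. With so little evidence, a large upward step in this assay is expected, though with wide uncertainty, and compound 1 at 116000 nM shows that the shared core can reach high numbers. The expected change is an at least 10-fold higher number from compound 2 to compound 3 (1.00 log units; beyond the scatter). For compound 3 the estimate is 50000 nM, with an expected range from 8000 nM to 200000 nM.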

Compound 3, solubility: 190000 nM
For compound 3 the middle estimate is 3.8-fold (0.58 log units) below the measured one; the measured number falls inside the stated range.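

In this assay, replacing methoxy with 4-methylpiperazin-1-yl on this carbon, para to a large group, gives an at least 38-fold higher number from compound 2 to compound 3 (1.57 log units; beyond the scatter). The earlier step only moved the methoxy group around its ring, whereas this one exchanges the group itself and shows that a new group at this same carbon can lift the read-out well clear of the lowest values seen. The true size of the step remains unknown, as compound 2 has only a limit of the assay and not a number: the limit of < 5000 nM in this assay, at which 1 of the 3 values shown sits.

From the compounds shown here alone, only one replacement for methoxy appears here, so it remains open whether an open-chain amine such as dimethylamino or a morpholine ring would give a similar number. Going by these compounds, it is also open whether 4-methylpiperazin-1-yl would act the same way at the place the methoxy group occupies in compound 1.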